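A Swapped Ring Pattern and Its Expected Effect

The source may hold more compounds than are shown below. What is called first, only, known or untested is meant among the compounds shown, and "the series" means these compounds.

Of the compounds shown here, three have been measured in a functional assay on HepG2 cells (Homo sapiens) for inhibition, read by MTT assay, with a stated time of 120 h; a lower number here means a stronger inhibitor, a higher number a weaker inhibitor. Compound 1 `CC(NC(=O)/C=C/c1ccc(NC(=O)Nc2ccc(Cl)c(C(F)(F)F)c2)cc1)c1ccccc1` gives 12200 nM. Compound 2 `CC(NC(=O)/C=C/Oc1ccc(NC(=O)Nc2cc(C(F)(F)F)ccc2Cl)cc1)c1ccccc1` gives 11900 nM, and compound 3 `CC(NC(=O)/C=C/Oc1ccc(NC(=O)Nc2ccc(Cl)c(C(F)(F)F)c2)cc1)c1ccccc1` gives 14100 nM. Compounds 2 and 3 differ in one place, (2-chloro-5-(trifluoromethyl)phenyl in place of 4-chloro-3-(trifluoromethyl)phenyl on an amide-type nitrogen), and this change produced a 1.2-fold lower number from compound 3 to compound 2 (0.07 log units; within the scatter). The difference between the core of compound 1 and the core of compound 3 is not broken down here. Compound 4 `CC(NC(=O)/C=C/c1ccc(NC(=O)Nc2cc(C(F)(F)F)ccc2Cl)cc1)c1ccccc1` is not yet measured; it arises from compound 1 by the same change, (2-chloro-5-(trifluoromethyl)phenyl in place of 4-chloro-3-(trifluoromethyl)phenyl on an amide-type nitrogen), at a place described in the same words. Because the earlier step of a 1.2-fold lower number from compound 3 to compound 2 (0.07 log units; within the scatter) stayed within the scatter, the step from compound 1 to compound 4 is expected to be similarly small, about a 1.2-fold lower number from compound 1 to compound 4 (0.07 log units; within the scatter). Compound 4 is therefore estimated at 10500 nM, with a likely range from 5000 nM to 22000 nM.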

Compound 4, half-maximal inhibitory concentration: 35900 nM
For compound 4 the middle estimate is 3.4-fold (0.53 log units) below the measured one; measured number above the stated range.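

In this assay, placing 2-chloro-5-(trifluoromethyl)phenyl where 4-chloro-3-(trifluoromethyl)phenyl stood gave a 2.9-fold higher number from compound 1 to compound 4 (0.47 log units; beyond the scatter), so on this core the change weakens inhibition. The change therefore does not carry over unaltered between the two cores: the same change on two cores in this assay, a 1.2-fold lower number (0.07 log units; within the scatter) from compound 3 to compound 2 and a 2.9-fold higher number (0.47 log units; beyond the scatter) from compound 1 to compound 4, 3.5-fold (0.54 log units) apart, beyond the scatter of two such steps. This shows that the size of the step depends on the core for this one pair of cores, but it does not show why, or what the change would do on a third core.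

The compounds shown also leave open what other groups would do on the same amide-type nitrogen. A phenyl ring carrying a nitrile or a carboxylic acid in place of the chlorine is one such case.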